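The source may report more compounds than this note shows. Statements on the series, on what has been measured and on what is new or still open speak of the compounds shown alone.

In a functional assay on MGC-803 cells (Homo sapiens) for inhibition, read by MTT assay, with a stated time of 48 h (on this read-out higher numbers stand for weaker inhibition and lower numbers for stronger inhibition), three compounds sharing one core have been measured. Compound 1 `COc1cc(Nc2nc(Nc3ccc(Cl)cc3)nnc2Cl)cc(OC)c1OC` gives 12600 nM and compound 2 `COc1cc(Nc2nc(Nc3ccc(C)cc3)nnc2Cl)cc(OC)c1OC` gives 19800 nM while compound 3 `COc1cc(Nc2nc(Nc3ccccc3)nnc2Cl)cc(OC)c1OC` gives 8750 nM with an unsubstituted anilino group. The position of compound 3 rests on two steps: one (a 1.4-fold lower number from compound 1 to compound 3 (0.16 log units; within the scatter)) stays within the scatter, and the other (a 2.3-fold lower number from compound 2 to compound 3 (0.35 log units; beyond the scatter)) is modest but beyond it. The remaining step (a 1.6-fold higher number from compound 1 to compound 2 (0.20 log units; within the scatter)) is again within the scatter.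

Compound 4 `COc1cc(Nc2nc(Nc3ccc(C(C)=O)cc3)nnc2Cl)cc(OC)c1OC` carries acetyl in place of hydrogen on an aromatic carbon, para to a large group (acetyl in place of hydrogen on an aromatic carbon). All three measured steps concern that same place, so they bear directly on this change, but only chloro and methyl have been measured there. None of these steps is large, so only a small move towards a higher number is expected in this assay here. The estimated step is (a 1.5-fold higher number from compound 3 to compound 4 (0.17 log units; within the scatter)) and may not clear the scatter. For compound 4 the estimate is 13000 nM with a range from 5500 nM to 30000 nM as the expected span.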

Compound 4, half-maximal inhibitory concentration: 13000 nM
Estimate against measurement, compound 4: no gap at the digits printed; the range from low to high includes it.
By their numbers in this assay, from the lowest: compounds 3, 1, 4 and 2 (each within the scatter of the next, the first and the last beyond it).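

In this assay, acetyl adds a carbonyl at this position, unlike chloro and methyl, yet its number stays within the scatter of all three earlier compounds (a 1.5-fold higher number from compound 3 to compound 4 (0.17 log units; within the scatter)) (a 1.5-fold lower number from compound 2 to compound 4 (0.18 log units; within the scatter)) (a 1.0-fold higher number from compound 1 to compound 4 (0.01 log units; within the scatter)). Among the compounds shown here, the position on the anilino group therefore accepts a group of this size without a step beyond the scatter, and the only such step among the four compounds remains the modest one between two earlier compounds (a 2.3-fold lower number from compound 2 to compound 3 (0.35 log units; beyond the scatter)). Nothing shown gives a reason for these numbers.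

The compounds shown leave open whether an amine, a carboxylic acid or a longer chain at this position would give a step clearly beyond the scatter. As far as these compounds go, whether acetyl would read the same with another group elsewhere on the shared core also stays open.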